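The compounds below may be only part of what the source reports. "The series", "measured", "known", "first", "only" and "open" are said of these compounds alone.

Measured so far in an assay on LtK cells with ATP-sensitive inward rectifier potassium channel 11 (Homo sapiens) as the target; on this read-out lower numbers stand for an effect already at smaller amounts and higher numbers for an effect only at larger amounts of compound:
- compound 1 `CC(=O)Nc1c(C(O)(C(F)(F)F)C(F)(F)F)ccc2ccccc12`: 18 nM
- compound 2 `O=C(CC1CCCC1)Nc1c(C(O)(C(F)(F)F)C(F)(F)F)ccc2ccccc12`: 81 nM
- compound 3 `O=C(Nc1c(C(O)(C(F)(F)F)C(F)(F)F)ccc2ccccc12)c1ccccc1`: 44 nM

Compound 1 gives the lowest of the three numbers in this assay. Its nearest neighbour is compound 3, with a 2.4-fold higher number from compound 1 to compound 3 (0.39 log units; beyond the scatter); the furthest is compound 2, with a 4.5-fold higher number from compound 1 to compound 2 (0.65 log units; beyond the scatter). Between the two larger groups on the carbonyl carbon the difference is small, a 1.8-fold lower number from compound 2 to compound 3 (0.27 log units; within the scatter).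

Compound 4 `O=C(Nc1c(C(O)(C(F)(F)F)C(F)(F)F)ccc2ccccc12)c1cccc(Cl)c1` differs from compound 1 by 3-chlorophenyl in place of methyl on a carbonyl carbon. Within the data shown here, the step that bears on it most directly is the one from compound 1 to compound 3, where phenyl in place of methyl on the carbonyl carbon gave a modest upward step. Among the measured compounds shown here, no measured pair shows the effect of chlorine on that ring, so that part of the change is unsupported by data. On the evidence of compound 3 a modest upward step in this assay is expected, a 2.8-fold higher number from compound 1 to compound 4 (0.44 log units; beyond the scatter). Compound 4 is therefore estimated at 50 nM, with a range from 20 nM to 130 nM.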

Compound 4, half-maximal effective concentration: 98 nM
Estimate against measurement, compound 4: 2.0-fold (0.29 log units) below; measured number inside the range.
By their numbers in this assay, from the lowest: compound 1; then compounds 3, 2 and 4 (each within the scatter of the next, the first and the last beyond it).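

In this assay, among these compounds, chloro in place of hydrogen on an aromatic carbon gives a 2.2-fold higher number from compound 3 to compound 4 (0.35 log units; beyond the scatter) and is the first read of a substituent on the ring carried by the carbonyl carbon: adding chlorine there moves the number beyond the scatter. Taken whole, 3-chlorophenyl in place of methyl on the carbonyl carbon gives a 5.4-fold higher number from compound 1 to compound 4 (0.74 log units; beyond the scatter) and this is the widest step shown, so the acetamido compound keeps the lowest number of the series. With a 1.2-fold higher number from compound 2 to compound 4 (0.08 log units; within the scatter) the 3-chlorophenyl and cyclopentylmethyl groups cannot be told apart on this read-out.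

On these data alone, how fluoro, methoxy or an amine on that ring would read remains open, as does the effect of chloro elsewhere on it. Nothing shown gives a reason for these steps.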